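The source may report more compounds than this note shows. Statements on the series, on what has been measured and on what is new or still open speak of the compounds shown alone.

Compound 1 `C[C@H](NC(=O)c1ccccc1)C(=O)N(C)/N=N/c1ccc(C#N)cc1` and compound 2 `CC(=O)N[C@H](C(=O)N(C)/N=N/c1ccc(C#N)cc1)C(C)C` carry different groups on the shared core. In a physicochemical assay for lipophilicity, read by HPLC, in phosphate buffer, measured as octanol-water partition, at pH 7.4 (on this read-out higher numbers stand for higher lipophilicity and lower numbers for lower lipophilicity), compound 1 gives 3.04 and compound 2 gives 2.18. Among the measured compounds shown here, compound 2 thus stands lowest of the two numbers measured so far, with compound 1 as its only neighbour, and that gap lies beyond the usual scatter. Compound 3 `CC(=O)N[C@@H](C)C(=O)N(C)/N=N/c1ccc(C#N)cc1` has not yet been measured. The change from compound 2 to compound 3 is methyl in place of isopropyl on a saturated chain carbon bound to an amide-type nitrogen and a carbonyl carbon. For the measured compounds named here, no step between measured compounds is available to calibrate it; the measured pair shows only that compound 2 sits well under compound 1 in this assay. The change removes heavy atoms from the side chain, and for compound 3 a downward step of a number 0.78 log units lower from compound 2 to compound 3 (beyond the scatter) is expected in this assay. Compound 3 is accordingly estimated to give about 1.4 in this assay, within a range from 0.9 to 1.9.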

Compound 3, partition coefficient: 1.41
Compound 3: middle estimate off by 0.01 log units, on the low side; the range from low to high includes it.
By their numbers in this assay, from the lowest: compound 3; then compound 2; then compound 1.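

In this assay the place on a saturated chain carbon bound to an amide-type nitrogen and a carbonyl carbon now has a calibrated step: methyl in place of isopropyl gives a number 0.77 log units lower from compound 2 to compound 3 (beyond the scatter) with one heavy-atom group replacing a larger one. On a carbonyl carbon, methyl in place of phenyl gives a number 1.63 log units lower from compound 1 to compound 3 (beyond the scatter) and is the larger of the two steps, so across these three compounds both places respond, and both read downward when methyl enters. Nothing measured speaks to the reason for either step.

As far as these compounds go, each place rests on a single change, so it remains open how a longer chain or a primary amine on the saturated chain carbon would read. A carboxylic acid or a cyclohexyl group on the carbonyl carbon would test the second place in the same way.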